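A few compounds are considered here, and "the series" means these few. Any claim that something is new, unique, unknown or untested is made for them only; others in the source may bear on it.

Three compounds have been measured so far in a functional assay on MCF7 cells (Homo sapiens) for inhibition, read by CCK-8 assay, with a stated time of 48 h; a higher number here means a weaker inhibitor, a lower number a stronger inhibitor:

Compound 1 `COc1ccc(-c2cc3nccc(-c4cc(OC)c(OC)c(OC)c4)n3n2)cc1N` gives 27 nM.
Compound 2 `COc1cc(-c2ccnc3cc(-c4ccc(-c5cnn(C)c5)cc4)nn23)cc(OC)c1OC` gives 274 nM.
Compound 3 `COc1cc(-c2ccnc3cc(-c4cn(C)c5ccccc45)nn23)cc(OC)c1OC` gives 95 nM.

Compound 3 therefore stands second highest of the three numbers. Within the data shown here, its nearest neighbour is compound 2, which gives a higher number than compound 3; further off lies compound 1, with a lower number, and the one single-site step measured, a 3.5-fold higher number from compound 1 to compound 3 (0.55 log units; beyond the scatter), places compound 3 clearly behind compound 1 in this assay.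

Compound 4 `C=Cc1ccc(-c2cc3nccc(-c4cc(OC)c(OC)c(OC)c4)n3n2)cc1` has not yet been measured. Set against compound 3, the change is 4-vinylphenyl in place of 1-methyl-1H-indol-3-yl on an aromatic carbon. Among the measured compounds shown here, no measured step repeats this exact exchange; the only one that bears on the same place is a 3.5-fold higher number from compound 1 to compound 3 (0.55 log units; beyond the scatter), which shows that swapping one aryl group for another there shifts the number by a modest amount. Compound 2, carrying yet another aryl group at that place, gives a higher number than compound 3. Because the measured exchanges at this place moved the number by steps such as a 3.5-fold higher number from compound 1 to compound 3 (0.55 log units; beyond the scatter), a comparable modest step or none beyond the scatter is expected: a 1.6-fold higher number from compound 3 to compound 4 (0.20 log units; within the scatter). Compound 4 is accordingly estimated to give about 150 nM, within the range 50 nM to 500 nM.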

Compound 4, half-maximal inhibitory concentration: 193 nM
Compound 4: the middle estimate sits 1.3-fold (0.11 log units) below what was measured, and the stated range covers the measured number.
By their numbers in this assay, from the lowest: compound 1; then compound 3; then compounds 4 and 2 (each within the scatter of the next).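

In this assay, 4-vinylphenyl in place of 1-methyl-1H-indol-3-yl gives a 2.0-fold higher number from compound 3 to compound 4 (0.31 log units; beyond the scatter) and so sits just beyond the scatter, while 4-vinylphenyl in place of 3-amino-4-methoxyphenyl gives the largest step yet seen at this place, a 7.1-fold higher number from compound 1 to compound 4 (0.85 log units; beyond the scatter) and thus widens the gap already opened by compound 3. Vinyl in place of 1-methyl-1H-pyrazol-4-yl gives a 1.4-fold lower number from compound 2 to compound 4 (0.15 log units; within the scatter) and so does not separate these two groups, although one brings a five-membered aromatic ring and the other only a double bond outside aromatic rings. No evidence is available to explain any of these differences.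

The compounds shown leave open how much of the gap to compound 1 belongs to the amine and how much to the methoxy group of its 3-amino-4-methoxyphenyl substituent. They also leave open how a longer chain or a carboxylic acid in place of the vinyl group would read at this place, and whether an amine added to the 4-vinylphenyl group would recover the lower number of compound 1.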